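The source may report more compounds than this note shows. Statements on the series, on what has been measured and on what is new or still open speak of the compounds shown alone.

Compound 1 `COc1ccc(N)cc1CS(=O)(=O)/C=C/c1c(OC)cccc1OC`: 25000 nM
Compound 2 `COc1ccc(CS(=O)(=O)/C=C/c2c(OC)cc(O)cc2OC)cc1[N+](=O)[O-]`: 5000 nM
Compound 3 `COC(=O)C(Nc1cc(CS(=O)(=O)/C=C/c2c(OC)cc(OC)cc2OC)ccc1OC)c1ccc(F)cc1`: 300 nM

These results come from a functional assay on DU-145 cells (Homo sapiens) for cytotoxicity, read by trypan blue exclusion, with a stated time of 96 h; on this read-out lower numbers stand for stronger inhibition and higher numbers for weaker inhibition. Among the three, compound 3 has the lowest number, at 300 nM, and the numbers of the other two lie above it, beyond the scatter. Compound 4 `COc1cc(OC)c(/C=C/S(=O)(=O)Cc2ccc(OC)c(NC(C(=O)O)c3ccc(F)cc3)c2)c(OC)c1` has not yet been measured. It differs from compound 3 in one place, methoxycarbonyl to carboxy, with hydrogen in place of methyl on an oxygen next to a carbonyl group. Going by the values given here, no measured pair shows this change, so the expectation is only a loose judgement. The expected change is a 3.3-fold higher number from compound 3 to compound 4 (0.52 log units; beyond the scatter), towards weaker inhibition in this assay and modestly beyond the scatter. The estimated value for compound 4 is 1000 nM, with an expected range from 150 nM to 6000 nM.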

Compound 4, half-maximal inhibitory concentration: 150 nM
For compound 4 the middle estimate is 6.7-fold (0.82 log units) above the measured one; low and high end bracket the measured number.
By their numbers in this assay, from the lowest: compounds 4 and 3 (each within the scatter of the next); then compound 2; then compound 1.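

In this assay the change from methoxycarbonyl to carboxy gives a 2.0-fold lower number from compound 3 to compound 4 (0.30 log units; within the scatter) and so leaves the read-out effectively unchanged. Going by these compounds alone, this is the first sign that the methyl on this oxygen can go without a measurable loss, and that a free carboxy group is tolerated here in this cell test. Nothing measured here explains this match. As far as these compounds go, whether a larger ester such as ethoxycarbonyl, or a primary amide in place of the carboxylic acid, would give a similar number remains open.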